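This account rests on a few compounds, and the source may have more. Where it says the series, first, only, none or still open, it means among the compounds named here.

Working notes on the series. In a functional assay on MCF7 cells (Homo sapiens) for cytotoxicity, read by MTT assay, with a stated time of 48 h (a lower number here means a stronger inhibitor, a higher number a weaker inhibitor), compound 1 (`COc1cc(/C=C/C(=O)/C=C/c2nc3cc(C)ccc3n2C)ccc1O`) gives 4500 nM, compound 2 (`COc1ccc(/C=C/C(=O)/C=C/c2nc3cc(C)ccc3n2C)cc1O`) gives 3600 nM, and compound 3 (`COc1ccc(/C=C/C(=O)/C=C/c2nc3c(C)c(C)ccc3n2C)cc1O`) gives 3500 nM. Compound 2 therefore lies within the scatter of both other compounds. Compound 4 (`COc1ccc(/C=C/C(=O)/C=C/c2nc3cc(O)ccc3n2C)cc1O`), not yet measured, has hydroxy in place of methyl on an aromatic carbon relative to compound 2: hydroxy in place of methyl on an aromatic carbon. Going by the values given here, the only measured step on the same six-membered aromatic ring, a 1.0-fold lower number from compound 2 to compound 3 (0.01 log units; within the scatter), is methyl in place of hydrogen and stays within the scatter. Among the compounds with values here, no measured step replaces methyl with hydroxy, so the evidence is indirect and the range is kept wide. No clear change is expected in this assay. The estimated step is a 1.2-fold lower number from compound 2 to compound 4 (0.08 log units; within the scatter), within the scatter. For compound 4 the expected value is 3000 nM, with an estimated range of 1200 nM to 7500 nM.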

Compound 4, half-maximal inhibitory concentration: 1900 nM
Beside the measured number, compound 4's estimate is 1.6-fold (0.20 log units) above it; the measured number falls inside the stated range.
By their numbers in this assay, from the lowest: compounds 4, 3, 2 and 1 (each within the scatter of the next, the first and the last beyond it).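

In this assay the exchange of methyl for hydroxy on this aromatic carbon gives a 1.9-fold lower number from compound 2 to compound 4 (0.28 log units; within the scatter). The earlier step on this ring added only a methyl, whereas this one brings in a hydrogen-bond donor and acceptor and still stays within the scatter, so this position accepts either group without a clear change in this read-out. Nothing available here bears on the reason for the size of this step. Going by these compounds, whether an amine or a carboxylic acid on this same aromatic carbon would move the number beyond the scatter remains open.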